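This account rests on a few compounds, and the source may have more. Where it says the series, first, only, none or still open, it means among the compounds named here.

Working notes on a small amide series assayed in an assay on CHO cells for displacement of a labelled ligand from transient receptor potential cation channel subfamily V member 1 (Rattus norvegicus); a higher number here means a weaker inhibitor, a lower number a stronger inhibitor. Compound 1 `CC(C)(C)c1ccc(CNC(=O)C2(c3ccc(NS(C)(=O)=O)cc3)CC2)cc1` gives 610 nM in this assay. Compound 2 `CC(C(=O)NCc1ccc(Cl)c(Cl)c1)c1ccc(NS(C)(=O)=O)c(F)c1` gives 200 nM. Compound 3 `CC(C(=O)NCc1ccc(C2C=CCC2)cc1)c1ccc(NS(C)(=O)=O)c(F)c1` gives 162 nM. Compound 2 stands second highest of the three numbers; its number and that of compound 3 lie within the scatter of each other, whereas compound 1 sits at a higher number, beyond the scatter. For the measured compounds named here, no two of the measured compounds differ in a single place, so no measured step is available to anchor the next change. Compound 4 `CC(C(=O)NCCCc1ccc(Cl)cc1)c1ccc(NS(C)(=O)=O)c(F)c1` has not yet been measured. It differs from compound 2 as follows: 2-(4-chlorophenyl)ethyl in place of 3,4-dichlorophenyl on a saturated chain carbon bound to an amide-type nitrogen. Going by the values given here, with no measured step of this kind, the expectation rests only on the three numbers already in hand, which span a fairly narrow band. The step of a 2.0-fold higher number from compound 2 to compound 4 (0.30 log units; within the scatter) is expected to be modest, toward a higher number, and may well fall within the scatter. Compound 4 is estimated to give about 400 nM in this assay, within a range from 120 nM to 1300 nM.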

Compound 4, inhibition constant: 470 nM
Beside the measured number, compound 4's estimate is 1.2-fold (0.07 log units) below it, within the range that was stated.
By their numbers in this assay, from the lowest: compounds 3 and 2 (each within the scatter of the next); then compounds 4 and 1 (each within the scatter of the next).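

In this assay, the change on a saturated chain carbon bound to an amide-type nitrogen gives the series its first single-place reading: 2-(4-chlorophenyl)ethyl in place of 3,4-dichlorophenyl brings a 2.4-fold higher number from compound 2 to compound 4 (0.37 log units; beyond the scatter) as a modest step beyond the scatter. The two groups differ both in their chlorine substitution and in the ethyl link, so this one step cannot be divided between those two differences. No measurement in hand accounts for the step.

Still open, on these data alone, is how a 2-(3,4-dichlorophenyl)ethyl group or an unsubstituted benzyl group would read at this place, which would help separate the contributions of the chlorine substitution and the link. Also open, as far as these compounds go, is whether a longer chain or a terminal amine would be tolerated here.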